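Swapping a chlorophenyl for thiophene on a hydrazone arm

A few compounds are considered here, and "the series" means these few. Any claim that something is new, unique, unknown or untested is made for them only; others in the source may bear on it.

Of the compounds shown here, two of one series have been tested in a functional assay on MGC-803 cells (Homo sapiens) for antiproliferative activity, read by MTT assay, with a stated time of 72 h; on this read-out higher numbers stand for weaker inhibition and lower numbers for stronger inhibition. Compound 1, `CCCSc1nc(N/N=C(\C)c2ccccc2O)c2nnn(Cc3ccco3)c2n1`, gives 4760 nM in this assay. Compound 2, `CCCSc1nc(N/N=C/c2ccccc2Cl)c2nnn(Cc3ccccc3)c2n1`, gives 10900 nM in this assay, the higher of the two numbers, so compound 2 is the weaker inhibitor of the pair, and the gap to compound 1 lies beyond the usual scatter of repeated measurements. The two compounds differ in more than one place, so nothing more than that comparison can be drawn from them.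

Compound 3, `CCCSc1nc(N/N=C/c2cccs2)c2nnn(Cc3ccccc3)c2n1`, has not yet been measured in this assay. It is built from compound 2 by a single change: thiophen-2-yl in place of 2-chlorophenyl on a carbon with a double bond to nitrogen. Within the data shown here, there is no measured pair in this set that isolates such a swap, so no measured step can guide the expectation. The step from compound 2 to compound 3 is therefore expected to be a 1.0-fold higher number from compound 2 to compound 3 (0.00 log units; within the scatter), that is, no change beyond the scatter. On that basis compound 3 is estimated to give 11000 nM in this assay, within a range from 4000 nM to 30000 nM.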

Compound 3, half-maximal inhibitory concentration: > 64000 nM
Compound 3: a limit, no number (the forecaster's own chance of this, stated with the estimate: 10%); middle value at least 5.8-fold (0.76 log units) from the limit.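

In this assay, the ring on a carbon with a double bond to nitrogen proves not to be freely exchangeable: thiophen-2-yl in place of 2-chlorophenyl gives an at least 5.8-fold higher number from compound 2 to compound 3 (0.76 log units; beyond the scatter), so this one change clearly weakens inhibition. The result for compound 3 is a limit of the assay and not a number, which means the step has a lower bound but no known full size: the limit of > 64000 nM in this assay, at which 1 of the 3 values shown sits. Compound 1 and compound 2 differ in more than one place, so they could not tie any change in activity to this position, whereas this pair does so directly.

A single step cannot separate the parts of the swap, which removes a chlorine, replaces a six-membered ring of carbon only with a five-membered ring, and brings in a sulfur. As far as these compounds go, it remains open where a plain phenyl ring or a furan-2-yl group at this place would fall relative to compound 2 and compound 3, and whether the same swap would act alike on the core of compound 1, with its furan-bearing arm.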